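A few compounds are considered here, and "the series" means these few. Any claim that something is new, unique, unknown or untested is made for them only; others in the source may bear on it.

For the measured compounds named here, in a functional assay on Caco-2 cells (Homo sapiens) for inhibition, read by MTT assay, with a stated time of 72 h (a higher number here means a weaker inhibitor, a lower number a stronger inhibitor), compound 1 `CC(C)CNC(=C\C(=O)/C=C/c1ccc(O)cc1)/C=C/c1ccc(O)cc1` gives 23000 nM and compound 2 `CCC(C)NC(=C\C(=O)/C=C/c1ccc(O)cc1)/C=C/c1ccc(O)cc1` gives 9400 nM as the lower of the two numbers so far. Compound 3 `O=C(/C=C(/C=C/c1ccc(O)cc1)NC1CCCCC1)/C=C/c1ccc(O)cc1` carries cyclohexyl in place of sec-butyl on an amine nitrogen. Going by the values given here, only one measured step bears on this change, sec-butyl in place of isobutyl (a 2.4-fold lower number from compound 1 to compound 2 (0.39 log units; beyond the scatter)), which is modest though beyond the scatter. That single step gives no direction for a ring, so a shift of similar modest size either way is possible, and no clear change is the expectation. The expected change is small (a 1.0-fold lower number from compound 2 to compound 3 (0.02 log units; within the scatter)). For compound 3 the estimated value is 9000 nM (expected range 3500 nM to 23000 nM).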

Compound 3, half-maximal inhibitory concentration: 7800 nM
The estimate for compound 3 lay 1.2-fold (0.06 log units) above the measured number; the measured number falls inside the stated range.
By their numbers in this assay, from the lowest: compounds 3 and 2 (each within the scatter of the next); then compound 1.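

In this assay, a ring on the amine nitrogen fits as well as an open branched group: cyclohexyl in place of sec-butyl gives a 1.2-fold lower number from compound 2 to compound 3 (0.08 log units; within the scatter). Against isobutyl, cyclohexyl gives a 2.9-fold lower number from compound 1 to compound 3 (0.47 log units; beyond the scatter), so compound 3 sits with compound 2, on the same side of compound 1. Nothing given here accounts for these numbers. Still open, going by these compounds, is how this position responds to a smaller ring such as cyclopropyl, a longer straight chain, or a chain ending in a carboxylic acid or an amine.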